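From Trimethoxyphenyl to Hydroxynaphthyl: An Expected Cytotoxicity

This account rests on a few compounds, and the source may have more. Where it says the series, first, only, none or still open, it means among the compounds named here.

Compound 1 `CN(C)CCn1cnnc1-c1cc(Oc2ccc(NC(=O)N/N=C/c3ccc(F)cc3F)cc2F)ccn1`: in a functional assay on A549 cells (Homo sapiens) for cytotoxicity, read by MTT assay, with a stated time of 72 h (on this read-out higher numbers stand for weaker inhibition and lower numbers for stronger inhibition), compound 1 gives 1870 nM.
Compound 2 `COc1cc(/C=N/NC(=O)Nc2ccc(Oc3ccnc(-c4nncn4CCN(C)C)c3)c(F)c2)cc(OC)c1OC`: in this assay compound 2 gives > 100000 nM, which is a limit of the assay and not a number.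

Compound 2 thus stands at the far end of the numbers shown: the limit of > 100000 nM in this assay, at which 1 of the 2 values shown sits. Compound 3 `CN(C)CCn1cnnc1-c1cc(Oc2ccc(NC(=O)N/N=C/c3c(O)ccc4ccccc34)cc2F)ccn1` differs from it by 2-hydroxynaphthalen-1-yl in place of 3,4,5-trimethoxyphenyl on a carbon with a double bond to nitrogen. For the measured compounds named here, the only measured step that bears on this is an at least 53-fold higher number from compound 1 to compound 2 (1.72 log units; beyond the scatter), where the trimethoxyphenyl group arrived and the number left the range of the assay. Its departure in compound 3 is therefore expected to bring a lower number, a step of an at least 16-fold lower number from compound 2 to compound 3 (1.22 log units; beyond the scatter). Compound 3 is estimated at 6000 nM, within 600 nM to 100000 nM.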

Compound 3, half-maximal inhibitory concentration: 880 nM
Estimate against measurement, compound 3: 6.8-fold (0.83 log units) above; the range from low to high includes it.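

In this assay, 2-hydroxynaphthalen-1-yl on a carbon with a double bond to nitrogen gives an at least 110-fold lower number from compound 2 to compound 3 (2.05 log units; beyond the scatter), so this place accepts a group with two aromatic rings and the loss seen with 3,4,5-trimethoxyphenyl does not extend to it. The same group gives a 2.1-fold lower number from compound 1 to compound 3 (0.33 log units; beyond the scatter), a modest gain over 2,4-difluorophenyl. Compound 2 stands at a limit of the assay and not at a number: the limit of > 100000 nM in this assay, at which 1 of the 3 values shown sits.

The compounds shown leave open whether the hydroxyl or the second ring accounts for this value. A plain naphthalen-1-yl group and a 2-hydroxyphenyl group would separate the two.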